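Inverting One Stereocentre of Compound 3

The source may report more compounds than this note shows. Statements on the series, on what has been measured and on what is new or still open speak of the compounds shown alone.

In an in vitro ADME assay on microsomes from liver (Rattus norvegicus) for metabolic stability (a higher number here means faster removal of the compound, a lower number slower removal), compound 3 `CC[C@@H](C)[C@@H]1C(=O)N[C@H](C2Cc3ccccc3C2)C(=O)N1[C@@H](C(=O)N1CCOCC1)c1ccc(C)nc1` gives 1 mL.min-1.g-1 and so stands level with its two measured neighbours: compound 1 `CC[C@H](C)[C@@H]1C(=O)N[C@H](C2Cc3ccccc3C2)C(=O)N1[C@@H](C(=O)N1CCOCC1)c1cnc(C)cc1C` gives 1 mL.min-1.g-1 and compound 2 `CCC(CC)[C@@H]1C(=O)N[C@H](C2Cc3ccccc3C2)C(=O)N1[C@@H](C(=O)N1CCOCC1)c1ccc(C)nc1` gives 1 mL.min-1.g-1 at the digits shown.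

Compound 4 `CC[C@H](C)[C@@H]1C(=O)N[C@H](C2Cc3ccccc3C2)C(=O)N1[C@@H](C(=O)N1CCOCC1)c1ccc(C)nc1` keeps every group of compound 3. The change between them is the two compounds have the same atoms and bonds and differ only in configuration as drawn: 1 of 4 stereo elements differ; a stereocentre at a saturated chain carbon is drawn R in compound 3 and S in compound 4 and nothing else: the two compounds have the same atoms and bonds, and a stereocentre at a saturated chain carbon is drawn R in compound 3 and S in compound 4.

Among the compounds with values here, one measured step bears on this, and only loosely. It is no change at the digits printed from compound 2 to compound 3 (within the scatter) with sec-butyl in place of pentan-3-yl on a saturated ring carbon, and it stays within the scatter. Within the data shown here, no measured pair isolates a change of configuration alone, so the evidence is indirect and the forecast carries real uncertainty.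

With all three measured compounds level, nothing points to a move in either direction. The step expected in this assay is an estimated no change at the digits printed from compound 3 to compound 4 (within the scatter) with nothing foreseen beyond the scatter. Compound 4 is expected at 1 mL.min-1.g-1 with an estimated range from 0.5 mL.min-1.g-1 to 3 mL.min-1.g-1 in this measurement.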

Compound 4, intrinsic clearance in microsomes: 1 mL.min-1.g-1
Beside the measured number, compound 4's estimate shows no gap at the digits printed; the range from low to high includes it.
By their numbers in this assay, from the lowest: compounds 1, 2, 3 and 4 (each within the scatter of the next).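

In this assay, inverting the stereocentre at the saturated chain carbon gives no change at the digits printed from compound 3 to compound 4 (within the scatter), so the drawn configuration there makes no visible difference to the clearance read-out. This is the first comparison in the set that tests configuration by itself rather than alongside a change of group, and it is a clean test for a simple reason: the fact that compounds 3 and 4 differ only in the configuration as drawn

The two other new comparisons fit the same flat picture: with sec-butyl in place of pentan-3-yl on a saturated ring carbon there is no change at the digits printed from compound 2 to compound 4 (within the scatter), and with hydrogen in place of methyl on an aromatic carbon there is no change at the digits printed from compound 1 to compound 4 (within the scatter).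

From the compounds shown here alone, only one of the four stereo elements has been tested here, so the effect of inverting any of the other three remains unknown. Going by these compounds, it also remains open whether a much longer chain or a carboxylic acid on the saturated ring carbon, or an amine in place of the methyl on the aromatic carbon, would leave the compound level with these four or move it beyond the scatter.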